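Compound 2 to compound 3: trifluoromethyl for methylcarbamoyl

The source may report more compounds than this note shows. Statements on the series, on what has been measured and on what is new or still open speak of the compounds shown alone.

Measured so far:
Compound 1 `Cc1cc(CO)cc(C)c1Oc1cc(Nc2ccc(C#N)cc2)c(N)cc1CO` gives 15900 nM
Compound 2 `CNC(=O)c1cc(N)c(Nc2ccc(C#N)cc2)cc1Oc1c(C)cc(CCC#N)cc1C` gives > 9100 nM (a limit of the assay)

Within the data shown here, both results come from an ADME assay on TZM cells (Homo sapiens) for cytotoxicity, read by XTT assay, with a stated time of 4 days (a lower number here means that less compound is tolerated, a higher number that more compound is tolerated), and no step between measured compounds is available. In this assay compound 1 gives a true number (15900 nM). Compound 2 stands at the limit of > 9100 nM in this assay, at which 1 of the 2 values shown sits; this is a limit of the assay and not a number.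

Compound 3 `Cc1cc(CCC#N)cc(C)c1Oc1cc(Nc2ccc(C#N)cc2)c(N)cc1C(F)(F)F` keeps the rest of compound 2 but has trifluoromethyl in place of methylcarbamoyl on an aromatic carbon, para to a (4-cyanophenyl)amino group (trifluoromethyl in place of methylcarbamoyl on an aromatic carbon). Among the measured compounds shown here, no measured pair covers this change, so no shift beyond the usual scatter is expected. For the measured compounds named here, the expectation leans on compound 1 with 15900 nM as the only number. The estimated size of the change is a step that the limit leaves unreadable from compound 2 to compound 3 and it is small. The estimated value for compound 3 in this assay is 10000 nM (expected range 3000 nM to 30000 nM).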

Compound 3, half-maximal cytotoxic concentration in the TZM assay: > 7100 nM
Compound 3 ended at the assay's limit (the forecaster's own chance of this, stated with the estimate: 45%); the middle value does not contradict the limit.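

In the TZM assay, compound 2 gives > 9100 nM, which is a limit of the assay and not a number. In the TZM assay, compound 3 gives > 7100 nM, which is also a limit of the assay and not a number. Among these compounds, no step between the two compounds can be read. The compounds shown leave open whether trifluoromethyl in place of methylcarbamoyl on an aromatic carbon shifts the true half-maximal cytotoxic concentration in the TZM assay at all. In a physicochemical assay for solubility, with a stated time of 4 h, at pH 7.4 (on this read-out lower numbers stand for lower solubility and higher numbers for higher solubility), compound 2 gives 8.28 ug/mL and compound 3 gives 0.24 ug/mL.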